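Swapping a Furan for a Thiophene on the Shared Core

This account rests on a few compounds, and the source may have more. Where it says the series, first, only, none or still open, it means among the compounds named here.

Measured so far:
compound 1 `CC1=C(C(=O)OCC(C)C)C(c2cccs2)NC(=O)N1` — 25%
compound 2 `CC1=C(C(=O)C2CC2)C(c2cccs2)NC(=O)N1` — 1%
compound 3 `CC1=C(C(=O)NC(C)C)C(c2ccoc2)NC(=O)N1` — 1%

In an assay on membranes from CHO cells for displacement of a labelled ligand from adenosine receptor A1 (Homo sapiens), read by scintillation counting, with a stated time of 60 min, tested at 1 uM (a lower number here means less inhibition, a higher number more inhibition at the concentration tested (going by the name of the read-out)), compound 3 gives 1%, level with compound 2 at the digits shown; together these two are the lowest of the three numbers, and compound 1 stands furthest away with a higher number beyond the scatter. Compound 4 `CC1=C(C(=O)NC(C)C)C(c2cccs2)NC(=O)N1` differs from compound 3 in one place: thiophen-2-yl in place of furan-3-yl on a saturated ring carbon. Among the compounds with values here, the only measured step, a number 24 percentage points lower from compound 1 to compound 2 (beyond the scatter), concerns the group on the carbonyl carbon while the five-membered ring stays unchanged, so it does not bear on this swap. The expectation therefore rests on compound 3 and compound 2 alone, both near the bottom of the range. A step of a number 4 percentage points higher from compound 3 to compound 4 (within the scatter) is expected, nothing beyond the scatter. Compound 4 is estimated at 5%, between -8% and 25%.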

Compound 4, a percentage reported as inhibition, at one concentration (the size of the read-out at that concentration, not a potency): 2%
For compound 4 the middle estimate is 3 percentage points above the measured one, and the stated range covers the measured number.
By their numbers in this assay, from the lowest: compounds 2, 3 and 4 (each within the scatter of the next); then compound 1.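

In this assay the step of a number 1 percentage points higher from compound 3 to compound 4 (within the scatter) for thiophen-2-yl in place of furan-3-yl on a saturated ring carbon means that the two rings cannot be told apart with the isopropylcarbamoyl group in place. With thiophen-2-yl held fixed, isopropylamino in place of cyclopropyl gives a number 1 percentage points higher from compound 2 to compound 4 (within the scatter) on the carbonyl carbon, while isopropylamino in place of isobutoxy gives a number 23 percentage points lower from compound 1 to compound 4 (beyond the scatter) and so only the isobutoxy compound stands apart.

On these data alone, what a phenyl ring or a longer alkyl chain would do on that saturated ring carbon remains open. Nothing available accounts for these numbers.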